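The source may report more compounds than this note shows. Statements on the series, on what has been measured and on what is new or still open speak of the compounds shown alone.

Measured so far:
Compound 1 `CCc1nc2c(OCc3ccccc3)cccn2c1N`: 83%
Compound 2 `CC(C)c1nc2c(OCc3ccccc3)cccn2c1N`: 0%

Among the measured compounds shown here, in a functional assay on the whole organism with Rattus norvegicus as the target, at a dose of 40 mg/kg by the intraperitoneal route (a higher number here means more inhibition at the dose given (going by the name of the read-out), a lower number less inhibition), compound 2 gives 0%, the lowest of the two numbers; the only measured step is a number 83 percentage points lower from compound 1 to compound 2 (beyond the scatter), a large drop that follows methyl in place of hydrogen on a saturated chain carbon. Compound 3 `CCCCc1nc2c(OCc3ccccc3)cccn2c1N` differs from compound 2 by butyl in place of isopropyl on an aromatic carbon. That one step bears on the change: the branched chain gave the low number, and butyl is again a straight chain, though longer than ethyl. Because compound 1 with its straight chain gives 83%, compound 3 is expected to give 45%, with a range from 5% to 85%. This expected rise means an estimated step of a number 45 percentage points higher from compound 2 to compound 3 (beyond the scatter).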

Compound 3, a percentage reported as inhibition, in the whole organism at one dose (the size of the read-out at that dose, not a potency): 26%
Estimate against measurement, compound 3: 19 percentage points above; the measured number falls inside the stated range.
By their numbers in this assay, from the lowest: compound 2; then compound 3; then compound 1.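

In this assay butyl gives back only part of what isopropyl lost, with a number 26 percentage points higher from compound 2 to compound 3 (beyond the scatter) and still a number 57 percentage points lower from compound 1 to compound 3 (beyond the scatter) at the same position. So among these three compounds, a straight chain alone does not restore the number seen with ethyl, and chain length counts here as well as branching. Nothing measured here explains either step. Still open, on these data alone, is where a propyl or methyl group would fall at this position, and whether a longer chain such as hexyl would lower the number further.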